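A few compounds are considered here, and "the series" means these few. Any claim that something is new, unique, unknown or untested is made for them only; others in the source may bear on it.

Of the compounds shown here, three of one shared core have been measured so far. Compound 1 `CC(C)(C)c1ccc(CN2C(=O)S/C(=C\c3ccc(N)cc3)C2=O)cc1` gives 66000 nM in a functional assay on CCRF-CEM cells (Homo sapiens) for cytotoxicity, read by cell counting, with a stated time of 3 days; a higher number here means a weaker inhibitor, a lower number a stronger inhibitor. Compound 2 `Nc1ccc(/C=C2\SC(=O)N(Cc3ccc(F)cc3)C2=O)cc1` gives 111000 nM in this assay, and compound 3 `CN1C(=O)S/C(=C\c2ccc(N)cc2)C1=O` gives 62000 nM. Compound 3 has the lowest number of the three, but its distance to compound 1 and to compound 2 is within the scatter, so no order among them can be read from these numbers.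

Compound 4 `Cc1ccc(CN2C(=O)S/C(=C\c3ccc(N)cc3)C2=O)cc1` differs from compound 3 in one place: 4-methylphenyl in place of hydrogen on a saturated chain carbon bound to an amide-type nitrogen in a ring. The step that bears most directly on this change runs the other way, from a 4-fluorophenyl to hydrogen at the same place, and it gave a 1.8-fold lower number from compound 2 to compound 3 (0.25 log units; within the scatter). The step of a 1.7-fold higher number from compound 1 to compound 2 (0.23 log units; within the scatter), which swaps one group on the aromatic carbon for another, shows that the two large groups at this place also stay within the scatter of each other. Together these steps suggest that adding a 4-methylphenyl at this place should move the number little, if at all.

Compound 4 is therefore expected to show roughly a 1.2-fold higher number from compound 3 to compound 4 (0.08 log units; within the scatter), a change not beyond the scatter. The estimate for compound 4 is 75000 nM, with a range from 35000 nM to 160000 nM.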

Compound 4, half-maximal inhibitory concentration: > 250000 nM
Compound 4: a limit, no number; the forecaster's own chance of this, stated with the estimate: 5%; at least 3.3-fold (0.52 log units) between middle value and limit.
By their numbers in this assay, from the lowest: compounds 3, 1 and 2 (each within the scatter of the next). At a limit, above all of these: compound 4.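

In this assay compound 4 gives no number, only a limit of the assay: the limit of > 250000 nM in this assay, at which 1 of the 4 values shown sits. Even so, the limit is enough to show a change beyond the scatter at this position, with an at least 4.0-fold higher number from compound 3 to compound 4 (0.60 log units; beyond the scatter) when 4-methylphenyl takes the place of hydrogen on a saturated chain carbon bound to an amide-type nitrogen in a ring. The outcome also turns on the group on the aromatic carbon: methyl in place of fluoro gives an at least 2.2-fold higher number from compound 2 to compound 4 (0.35 log units; beyond the scatter), and methyl in place of tert-butyl gives an at least 3.7-fold higher number from compound 1 to compound 4 (0.57 log units; beyond the scatter), whereas the fluoro and tert-butyl compounds stay within the scatter of each other, so compounds 1 and 2 go against any idea that the ring alone sets the result.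

The true size of these three steps remains unknown, and the compounds shown do not explain why methyl stands apart from both fluoro and tert-butyl. From the compounds shown here alone, it also remains open whether a chloro or methoxy group on that aromatic carbon would behave like the methyl of compound 4 or like the groups of compounds 1 and 2.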